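From anilinomethyl to acetyl: a stability estimate

This account rests on a few compounds, and the source may have more. Where it says the series, first, only, none or still open, it means among the compounds named here.

Of the compounds shown here, three sharing one core have been measured in an ADME assay on microsomes from liver (Homo sapiens) for metabolic stability, read by LC-MS, with a stated time of 1 h; a lower number here means that less of the compound is left, a higher number that more of the compound is left. Compound 1 (`O=[N+]([O-])c1cn2c(n1)OC[C@@H](OCc1ccc(-c3ccccc3OCCCO)cc1)C2`) gives 59% and compound 2 (`O=[N+]([O-])c1cn2c(n1)OC[C@@H](OCc1ccc(-c3cccc(OCc4ccccc4)c3)cc1)C2`) gives 64%, two values within the scatter of each other. Compound 3 (`O=[N+]([O-])c1cn2c(n1)OC[C@@H](OCc1ccc(-c3ccc(CNc4ccccc4)cc3)cc1)C2`) gives 12%, the lowest of the three numbers, and its gap to each of the other two lies beyond the scatter.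

Compound 4 (`CC(=O)c1ccc(-c2ccc(CO[C@@H]3COc4nc([N+](=O)[O-])cn4C3)cc2)cc1`) has not yet been measured. It carries acetyl in place of the anilinomethyl of compound 3, on an aromatic carbon of a six-membered aromatic ring of carbon only, para to a large group: acetyl in place of anilinomethyl on an aromatic carbon.

Among the measured compounds shown here, no measured pair isolates this change, so its size in this assay cannot be read directly and rests on thin evidence. Among the measured compounds, anilinomethyl occurs only in compound 3 at 12%, whereas it is absent from compound 1 at 59% and from compound 2 at 64%. On that basis, a rise beyond the scatter is expected. The estimated change is a number 46 percentage points higher from compound 3 to compound 4 (beyond the scatter). For compound 4 the expected value is 58%, with an estimated range of 35% to 82%.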

Compound 4, percent of the compound remaining: 36%
The estimate for compound 4 lay 22 percentage points above the measured number; the measured number falls inside the stated range.
By their numbers in this assay, from the lowest: compound 3; then compound 4; then compounds 1 and 2 (each within the scatter of the next).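

In this assay, among the compounds shown here, the exchange of anilinomethyl for acetyl on an aromatic carbon, para to a large group, gives a number 24 percentage points higher from compound 3 to compound 4 (beyond the scatter), a direct reading of a change at this position that the earlier compounds could only suggest. With the rest of the molecule the same, this one exchange moves the number beyond the scatter, so the substituent at this position bears on how much of the compound is left. Nothing at hand gives a measured property that accounts for this step.

Going by these compounds, the step removes the ring and the hydrogen-bond donor of anilinomethyl and brings in the carbonyl of acetyl all at once, so the share of each in the rise remains open. Also open, on these data alone, is how an aminomethyl, a carboxylic acid or a longer chain on the same aromatic carbon would read in this assay, and whether acetyl would produce a step of similar size if the rest of the molecule were different.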